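This account rests on a few compounds, and the source may have more. Where it says the series, first, only, none or still open, it means among the compounds named here.

Measured so far in an assay for inhibition of Alpha amylase (Homo sapiens), with a stated time of 10 min; on this read-out lower numbers stand for stronger inhibition and higher numbers for weaker inhibition:

- compound 1 `Oc1ccc(/C=N/n2cnnc2)cc1O` — 5690 nM
- compound 2 `Oc1ccc(O)c(/C=N/n2cnnc2)c1` — 5270 nM
- compound 3 `Oc1ccc(/C=N/n2cnnc2)c(O)c1O` — 5920 nM

All three values lie within the scatter of one another. Going by the values given here, compound 1 sits in the middle of this narrow band; the one single-point step that touches it, a 1.0-fold higher number from compound 1 to compound 3 (0.02 log units; within the scatter), is flat, and the gap between compound 1 and compound 2 is likewise within the scatter. Among the compounds with values here, no pair among the three stands apart.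

Compound 4 `COc1cc(/C=N/n2cnnc2)ccc1O` is not yet measured. Against compound 1 the change is methyl in place of hydrogen on an oxygen on an aromatic ring. Within the data shown here, no measured step in this assay tests a methyl on an aromatic oxygen; the only step that bears on the same part of the core is the hydroxy-for-hydrogen change from compound 1 to compound 3, which gave no movement beyond the scatter. Among the measured compounds shown here, with the whole series flat and no step pointing either way, the expected change for compound 4 in this assay is a 1.0-fold higher number from compound 1 to compound 4 (0.00 log units; within the scatter), meaning none beyond the scatter. Compound 4 is therefore estimated at 5700 nM, with a range from 2500 nM to 13000 nM.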

Compound 4, half-maximal inhibitory concentration: 5940 nM
Compound 4: middle estimate off by 1.0-fold (0.02 log units), on the low side, within the range that was stated.
By their numbers in this assay, from the lowest: compounds 2, 1, 3 and 4 (each within the scatter of the next).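

In this assay the change from hydroxy to methoxy gives a 1.0-fold higher number from compound 1 to compound 4 (0.02 log units; within the scatter) and so shows that methyl can replace the hydrogen on this oxygen with no shift beyond the scatter. Going by these compounds alone, compounds 1, 2 and 3 carry only free hydroxy groups, so compound 4 is the first to show a change made on the oxygen itself rather than on an aromatic carbon. No supporting data bear on why this step is flat.

On these data alone, whether a larger group on this oxygen, such as an ethyl group or a longer chain, would also leave the number within the scatter remains open. So does the outcome of replacing this hydroxy with an amine or a carboxylic acid, since no step among the compounds shown yet moves the number beyond the scatter.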